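The compounds below may be only part of what the source reports. "The series", "measured", "known", "first", "only" and "open" are said of these compounds alone.

Measured compounds:
compound 2 `COC(=O)[C@@]1(C)CC[C@@H]2C3=C1CC[C@@H](C)[C@]3(C)Cc1c2[nH]c2ccccc12` with 3200 nM in a functional assay on HeLa cells (Homo sapiens) for inhibition, read by sulforhodamine B assay, with a stated time of 48 h; on this read-out higher numbers stand for weaker inhibition of growth and lower numbers for stronger inhibition of growth;
compound 1 `COC(=O)[C@@]1(C)CCC=C2[C@@H]1CC[C@@H](C)[C@]2(C)Cc1c(C)[nH]c2ccc(F)cc12` with 11000 nM in this assay.

Compound 2 stands at the lower of the two numbers: compound 1, its nearest neighbour, gives a higher number, a gap beyond the usual scatter. Among the measured compounds shown here, the two compounds differ in more than one place, so no single step between them can be read off; their values show only that compound 2 inhibits growth more strongly.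

The step to compound 3 `COC(=O)[C@@]1(C)CC[C@@H]2C3=C1CC[C@@H](C)[C@]3(C)Cc1c2[nH]c2ccc(Br)cc12` keeps the core of compound 2 and changes one place: bromo in place of hydrogen on an aromatic carbon. For the measured compounds named here, nothing among the measured compounds tests this change on its own. Without such a comparison, the expected step is small, and the direction is uncertain; a change no larger than the scatter, or a modest move toward stronger inhibition of growth, seems most likely. On that basis compound 3 is expected to give 2500 nM in this assay, within 800 nM to 8000 nM, corresponding to an expected step of a 1.3-fold lower number from compound 2 to compound 3 (0.11 log units; within the scatter).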

Compound 3, concentration for 50% growth inhibition: 14000 nM
For compound 3 the middle estimate is 5.6-fold (0.75 log units) below the measured one, and the stated range ends below it.
By their numbers in this assay, from the lowest: compound 2; then compounds 1 and 3 (each within the scatter of the next).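

Among the compounds shown here, this is the first comparison in the set that isolates one change. In this assay, bromo in place of hydrogen on an aromatic carbon gives a 4.4-fold higher number from compound 2 to compound 3 (0.64 log units; beyond the scatter) and so weaker inhibition of growth on the core of compound 2. The position therefore matters to this read-out: on the six-membered aromatic ring of carbon only, meta to a fused ring and para to a fused ring, one added bromine atom is enough to move the number beyond the scatter, and it moves it toward weaker inhibition. The compounds shown offer no measurement that bears on why the number rises.

From the compounds shown here alone, whether this loss is particular to bromo or would follow from other groups on the same aromatic carbon stays open, and a methoxy group, an amine or a carboxylic acid there would begin to separate those possibilities. Going by these compounds, it is also open whether bromo at this place would shift the number in the same direction on the core of compound 1 as it does on the core of compound 2.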